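A few compounds are considered here, and "the series" means these few. Any claim that something is new, unique, unknown or untested is made for them only; others in the source may bear on it.

In an ADME assay on L6 cells (Rattus norvegicus) for cytotoxicity (on this read-out higher numbers stand for weaker inhibition and lower numbers for stronger inhibition), compound 1 `COc1c(C(=N)N)cccc1-c1cc(-c2cccc(C(=N)N)c2)no1` gives 125000 nM, and compound 2 `N=C(N)c1cccc(-c2cc(-c3cccc(C(=N)N)c3[N+](=O)[O-])no2)c1` gives 177000 nM. Compound 3 `COc1c(C(=N)N)cccc1-c1cc(-c2cccc(C(=N)N)c2)on1` stands only at a limit of the assay, > 214000 nM. It therefore has no exact place on the scale. Compound 4 `COc1c(C(=N)N)cccc1-c1cc(-c2cccc(C(=N)N)c2OC)on1` differs from it by methoxy in place of hydrogen on an aromatic carbon. Within the data shown here, one measured step bears on this change, though only loosely: an at least 1.2-fold higher number from compound 2 to compound 3 (0.08 log units; that floor lies within the scatter), where methoxy replaces nitro on an aromatic carbon, and that floor lies within the scatter. On that slender basis, no shift beyond the scatter is expected in this assay, and the expected step is a step that the limit leaves unreadable from compound 3 to compound 4. The estimate for compound 4 is 220000 nM, with an expected range from 100000 nM to 450000 nM.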

Compound 4, half-maximal inhibitory concentration: 79900 nM
Compound 4: the middle estimate sits 2.8-fold (0.44 log units) above what was measured; measured number below the stated range.
By their numbers in this assay, from the lowest: compounds 4, 1 and 2 (each within the scatter of the next, the first and the last beyond it). At a limit, above all of these: compound 3.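

In this assay, methoxy on this aromatic carbon, ortho to a group of 3 heavy atoms, gives a step beyond the scatter: an at least 2.6-fold lower number from compound 3 to compound 4 (0.42 log units; beyond the scatter). That size is only a floor, since the value of compound 3 is a limit: the limit of > 214000 nM in this assay, at which 1 of the 4 values shown sits. The same change stays within the scatter in the other comparison, a 1.6-fold lower number from compound 1 to compound 4 (0.19 log units; within the scatter), so the two steps do not agree in showing a shift beyond the scatter. Still open, as far as these compounds go, is whether an amine, a hydroxyl or a longer chain on this carbon would read like methoxy in this assay.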